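Dimethoxyphenyl for Ethyl on the Ring Nitrogen

The source may report more compounds than this note shows. Statements on the series, on what has been measured and on what is new or still open speak of the compounds shown alone.

Compound 1 `COc1ccccc1N1C(=O)CSC1c1cccc(C(=O)NCCCCn2cncn2)c1`: > 1000 nM
Compound 2 `CCN1C(=O)CSC1c1cccc(C(=O)NCCCCc2ccccc2)c1`: > 1000 nM

Both compounds were tested in a functional assay on HOS-TE85 cells (Homo sapiens) for inhibition, read by CCK-8 assay, with a stated time of 72 h; on this read-out lower numbers stand for stronger inhibition and higher numbers for weaker inhibition. The value of compound 1 there, > 1000 nM, is a limit of the assay rather than a number. Compound 2 likewise gives only a limit in this assay, > 1000 nM. So compound 2 stands at the limit of > 1000 nM in this assay, at which 2 of the 2 values shown sit; nothing finer can be said about it from the numbers shown.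

Compound 3 `COc1ccc(N2C(=O)CSC2c2cccc(C(=O)NCCCCc3ccccc3)c2)c(OC)c1` has not been measured in this assay. It differs from compound 2 in one place: 2,4-dimethoxyphenyl in place of ethyl on an amide-type nitrogen in a ring.

Among the compounds with values here, no measured step exists for this kind of change, so no direction can be read from the data. The expected step from compound 2 to compound 3 in this assay is a step that the limit leaves unreadable from compound 2 to compound 3, that is, none beyond the scatter, because the limit of > 1000 nM in this assay, at which 2 of the 2 values shown sit, is all the measured compounds show. Compound 3 is therefore estimated at 3000 nM, within a range from 800 nM to 15000 nM.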

Compound 3, half-maximal inhibitory concentration: 90.4 nM
The estimate for compound 3 lay 33-fold (1.52 log units) above the measured number, outside the stated range (below it).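

In this assay, the group on the amide-type nitrogen in the ring proves to matter: 2,4-dimethoxyphenyl in place of ethyl gives an at least 11-fold lower number from compound 2 to compound 3 (1.04 log units; beyond the scatter). That lower number means stronger inhibition, and compound 3 is the first compound shown with a value that is a number rather than a limit. Before it, nothing could be read about this position, because the earlier compounds gave only limits: the limit of > 1000 nM in this assay, at which 2 of the 3 values shown sit.

The compounds shown do not reveal whether the gain comes from the aromatic ring itself or from its two methoxy groups, and a plain phenyl or a cyclohexyl on that nitrogen would help separate these possibilities. As far as these compounds go, the true size of the step also stays open, since the value of compound 2 is a limit.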